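This account rests on a few compounds, and the source may have more. Where it says the series, first, only, none or still open, it means among the compounds named here.

Compound 1 `COc1ccc(Cl)cc1S(=O)(=O)Nc1cncc(-c2cccnc2)c1`, measured in an assay on isolated protein for inhibition of alkaline phosphatase, tissue-nonspecific isozyme (Homo sapiens) (a higher number here means a weaker inhibitor, a lower number a stronger inhibitor), gives 73 nM.
Compound 2 `COc1ccc(OC)c(S(=O)(=O)Nc2cncc(-c3ccncc3)c2)c1` gives 73 nM.
Compound 3 `COc1ccc(Cl)cc1S(=O)(=O)Nc1cncc(C(=O)Nc2ccccc2)c1` gives 310 nM.

Compound 3 stands at the highest number of the three, that is, it is the weakest inhibitor among them; compound 1 and compound 2 each sit at a lower number by the same margin, a gap that is beyond the scatter. Among the compounds with values here, the one change seen so far in this group, a 4.2-fold higher number from compound 1 to compound 3 (0.63 log units; beyond the scatter), shows that swapping the pyridin-3-yl ring of compound 1 for phenylcarbamoyl costs inhibition.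

Compound 4 `COC(=O)c1cncc(NS(=O)(=O)c2cc(Cl)ccc2OC)c1` differs from compound 3 in a single place: methoxy in place of anilino on a carbonyl carbon. Within the data shown here, no measured pair shows this particular exchange, so nothing here tells how much the anilino part of the phenylcarbamoyl group contributes to the result of compound 3. Among the measured compounds shown here, the only guidance is that compound 3 is already the weakest of the three measured compounds and that compound 4 carries an even smaller group at the same carbonyl carbon. The expectation is therefore a step of a 1.5-fold higher number from compound 3 to compound 4 (0.16 log units; within the scatter), a small further rise in the number that may or may not exceed the scatter. Compound 4 is thus estimated at 450 nM, within a range from 130 nM to 1500 nM.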

Compound 4, half-maximal inhibitory concentration: 65 nM
Compound 4: middle estimate off by 6.9-fold (0.84 log units), on the high side, outside the stated range (below it).
By their numbers in this assay, from the lowest: compounds 4, 1 and 2 (each within the scatter of the next); then compound 3.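

In this assay, the step of a 4.8-fold lower number from compound 3 to compound 4 (0.68 log units; beyond the scatter) shows that this carbonyl carbon does not need the anilino group: methoxy, with 2 heavy atoms against 7 and no ring, gives the lower number, so the cost seen with phenylcarbamoyl goes with the anilino part. The step of a 1.1-fold lower number from compound 1 to compound 4 (0.05 log units; within the scatter) lies within the scatter, so methoxycarbonyl and pyridin-3-yl cannot be told apart on this aromatic carbon, although only one of them brings a ring. Among the three groups compared on this carbon in the shared core, a ring is therefore not required to reach this level of inhibition, and phenylcarbamoyl is the one that stands apart.

No measurement at hand gives a reason for these differences. From the compounds shown here alone, it remains open whether the methoxy matters in its own right or simply avoids the cost of anilino, and a carboxylic acid, a methylamino group or a longer ester such as ethoxycarbonyl on the same carbonyl carbon would help separate the effect of size from that of the amide hydrogen.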